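Ester to Primary Amide on the Aryl Urea Chain

This account rests on a few compounds, and the source may have more. Where it says the series, first, only, none or still open, it means among the compounds named here.

Among the compounds with values here, compound 3 `COC(=O)c1ccc(NC(=O)Nc2cc(C)nc3ccccc23)cc1` carries the only number among the three measured compounds. In an ADME assay on HEK293 cells (Homo sapiens) for cytotoxicity, with a stated time of 72 h (on this read-out higher numbers stand for an effect only at larger amounts of compound and lower numbers for an effect already at smaller amounts), compound 3 gives 15000 nM. Compound 1 `Cc1ccc(NC(=O)Nc2cc(C)nc3ccccc23)cc1` returns a limit of the assay rather than a number, > 25000 nM. Compound 2 `CC(=O)c1ccc(NC(=O)Nc2cc(C)nc3ccccc23)cc1` likewise returns a limit and not a number, > 25000 nM, so that two of the three values sit at the limit of > 25000 nM in this assay, at which 2 of the 3 values shown sit. The change to compound 4 `Cc1cc(NC(=O)Nc2ccc(C(N)=O)cc2)c2ccccc2n1` is amino in place of methoxy on a carbonyl carbon. The closest measured step is an at least 1.6-fold lower number from compound 2 to compound 3 (0.22 log units; that floor lies within the scatter), and an at least 1.6-fold lower number from compound 1 to compound 3 (0.22 log units; that floor lies within the scatter) is of the same kind, both within the scatter; a step that the two limits leave unreadable from compound 1 to compound 2. Compound 4 is therefore expected to stay close to compound 3, with an expected step of a 1.3-fold higher number from compound 3 to compound 4 (0.12 log units; within the scatter). The estimate for compound 4 is 20000 nM, between 8000 nM and 50000 nM.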

Compound 4, half-maximal effective concentration: > 25000 nM
Compound 4 ended at the assay's limit; the forecaster's own chance of this, stated with the estimate: 50%; middle value at least 1.2-fold (0.09 log units) from the limit.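

Amino in place of methoxy on a carbonyl carbon gives an at least 1.6-fold higher number from compound 3 to compound 4 (0.22 log units; that floor lies within the scatter) in this assay, so the only readable step at this position has a floor and no upper bound. Compound 4 returns a limit of the assay, > 25000 nM. Compound 3 remains the only compound with a number: the limit of > 25000 nM in this assay, at which 3 of the 4 values shown sit.

The steps from compound 1 and from compound 2 to compound 4 cannot be read, since both ends are limits. From the compounds shown here alone, whether a carboxylic acid or a longer ester chain at this carbonyl carbon would give a number remains open.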